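A few compounds are considered here, and "the series" means these few. Any claim that something is new, unique, unknown or untested is made for them only; others in the source may bear on it.

Compound 1, `CN(C)C1(Cc2ccccc2)CCN(c2cc(C(F)(F)F)ccc2CNC(=O)Nc2ccc(NS(C)(=O)=O)c(F)c2)CC1`: 1160 nM
Compound 2, `CN(C)C1(Cc2ccccc2)CCN(c2cc(C(F)(F)F)ccc2CNC(=O)Nc2ccc(CO)c(F)c2)CC1`: 27.9 nM
Compound 3, `CN(C)C1(Cc2ccccc2)CCN(c2cc(C(F)(F)F)ccc2CNC(=O)Nc2cccc3c2CC(O)CC3)CC1`: 0.95 nM

In an assay on CHO cells for displacement of a labelled ligand from transient receptor potential cation channel subfamily V member 1 (Homo sapiens), read by scintillation counting, with a stated time of 60 min (a higher number here means a weaker inhibitor, a lower number a stronger inhibitor), compound 3 gives the lowest number of the three. The gap to its nearest neighbour is a 29-fold lower number from compound 2 to compound 3 (1.47 log units; beyond the scatter), and the gap to the furthest is a 1200-fold lower number from compound 1 to compound 3 (3.09 log units; beyond the scatter), both well beyond the scatter, so compound 3 is the strongest inhibitor of this set.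

Compound 4, `CN(C)C1(Cc2ccccc2)CCN(c2cc(C(F)(F)F)ccc2CNC(=O)Nc2cccc3[nH]c(=O)ccc23)CC1`, differs from compound 3 only at the urea nitrogen: a group of 11 heavy atoms (9 carbon, 1 nitrogen, 1 oxygen; one six-membered aromatic ring of carbon only, one six-membered aromatic ring with 1 hetero atom) in place of a group of 11 heavy atoms (10 carbon, 1 oxygen; one six-membered non-aromatic ring of carbon only, one six-membered aromatic ring of carbon only), on an amide-type nitrogen. Within the data shown here, none of the measured steps makes this exact change, so no step bears on it directly. What the measured steps show is that moving from either phenyl group to the bicyclic group was worth a large amount, a 29-fold lower number from compound 2 to compound 3 (1.47 log units; beyond the scatter) and a 1200-fold lower number from compound 1 to compound 3 (3.09 log units; beyond the scatter), while a change within the phenyl series, a 42-fold lower number from compound 1 to compound 2 (1.62 log units; beyond the scatter), was also large. Compound 4 keeps a bicyclic group of the same size with one donor and one acceptor, so in this assay a step of about a 2.6-fold higher number from compound 3 to compound 4 (0.42 log units; beyond the scatter) is expected, at most a modest rise and possibly none beyond the scatter. Compound 4 is therefore estimated at 2.5 nM in this assay, within a range of 0.5 nM to 15 nM.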

Compound 4, inhibition constant: 1.67 nM
Beside the measured number, compound 4's estimate is 1.5-fold (0.18 log units) above it, and the stated range covers the measured number.
By their numbers in this assay, from the lowest: compounds 3 and 4 (each within the scatter of the next); then compound 2; then compound 1.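

At the amide-type nitrogen, the 3-hydroxy-1,2,3,4-tetrahydronaphthalen-5-yl group can give way to a group carrying a six-membered aromatic ring with 1 hetero atom, with no change beyond the scatter in this assay: a 1.8-fold higher number from compound 3 to compound 4 (0.24 log units; within the scatter). The large advantage over the phenyl groups therefore does not belong to compound 3's group alone, since it also appears in a 17-fold lower number from compound 2 to compound 4 (1.22 log units; beyond the scatter) and in a 690-fold lower number from compound 1 to compound 4 (2.84 log units; beyond the scatter), so a non-aromatic ring of carbon only is not needed at this place to reach such low numbers. No measurement given here accounts for why the two bicyclic groups stand level or why both stand so far from the phenyl groups.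

The compounds shown leave open how much of this level standing depends on the oxygen of each group, for instance whether an amine in its place would hold the number. They also leave open whether the two bicyclic groups would stay level on a changed core, such as one with a nitrile in place of the trifluoromethyl.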